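This account rests on a few compounds, and the source may have more. Where it says the series, first, only, none or still open, it means among the compounds named here.

- compound 1 `CC(C)[C@H](C[C@H]1OC(=O)NC1=O)c1ccc(-c2ccc3cccc(F)c3c2)[nH]c1=O`: 0.95 h
- compound 2 `CC(C)C(CC1NC(=O)NC1=O)c1ccc(-c2ccc3cccc(F)c3c2)[nH]c1=O`: 0.35 h

In an ADME assay on microsomes from liver (Rattus norvegicus) for metabolic stability (a lower number here means that the compound disappears faster, a higher number that the compound lasts longer), compound 1 gives 0.95 h, the higher of the two numbers, and the gap down to compound 2 at 0.35 h lies beyond the scatter. Compound 3 `CC(C)[C@H](C[C@@H]1OC(=O)NC1=O)c1ccc(-c2ccc3cccc(F)c3c2)[nH]c1=O` is the next case, with this change from compound 1: the two compounds have the same atoms and bonds and differ only in configuration as drawn: 1 of 2 stereo elements differ; a stereocentre at a saturated ring carbon is drawn R in compound 1 and S in compound 3. Among the compounds with values here, no measured pair shows what such a change in configuration does, so the expectation starts from compound 1 at 0.95 h. The expected move is a 1.1-fold lower number from compound 1 to compound 3 (0.05 log units; within the scatter), with no direction favoured and nothing beyond the scatter. Compound 3 is estimated at 0.85 h, with a range of 0.4 h to 1.8 h.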

Compound 3, half-life: 0.503 h
For compound 3 the middle estimate is 1.7-fold (0.23 log units) above the measured one; low and high end bracket the measured number.
By their numbers in this assay, from the lowest: compounds 2, 3 and 1 (each within the scatter of the next, the first and the last beyond it).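

In this assay the series now has its first reading of a swapped configuration at this saturated ring carbon: a 1.9-fold lower number from compound 1 to compound 3 (0.28 log units; within the scatter). That step stays within the scatter, so no effect of this stereocentre on half-life is established, whichever way it is drawn. The comparison is structurally clean: the fact that compounds 1 and 3 differ only in the configuration as drawn

The compounds shown leave open whether the other stereo element matters in the same assay. They also leave open how a carboxylic acid or an amine in place of this saturated ring would behave.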